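This account rests on a few compounds, and the source may have more. Where it says the series, first, only, none or still open, it means among the compounds named here.

In an assay on microsomes from intestine for inhibition of acyl-CoA:cholesterol acyltransferase (Oryctolagus cuniculus) (a higher number here means a weaker inhibitor, a lower number a stronger inhibitor), the three measured compounds give these numbers:

compound 1, `Cc1cc(C)c(NC(=O)N(Cc2c[nH]c(-c3ccccc3)n2)C2CCCCCC2)c(C)c1`: 750 nM
compound 2, `Cc1cc(C)c(NC(=O)N(Cc2cccc(-c3nnn(C)n3)c2)C2CCCCCC2)c(C)c1`: 100 nM
compound 3, `Cc1cc(C)c(NC(=O)N(Cc2ccc(-c3cc[nH]n3)cc2)C2CCCCCC2)c(C)c1`: 52 nM

Compound 2 stands second highest of the three numbers. Compound 3 gives a number within the scatter of compound 2, so those two cannot be told apart. Compound 1 gives a number higher than compound 2 by more than the scatter, so compound 1 is the weaker inhibitor of that pair.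

Compound 4, `Cc1cc(C)c(NC(=O)N(Cc2cccc(-c3cc[nH]n3)c2)C2CCCCCC2)c(C)c1`, has not yet been measured. It differs from compound 2 in one place: 1H-pyrazol-3-yl in place of 2-methyl-2H-tetrazol-5-yl on an aromatic carbon. Going by the values given here, no measured pair shows this change on its own, so its size is not known from direct comparison. Compound 3 also carries a 1H-pyrazol-3-yl group on the six-membered aromatic ring of carbon only, and its number stays within the scatter of compound 2, so there is no sign that this group by itself drives a large move. The step from compound 2 to compound 4 is therefore expected to be small, a 1.4-fold lower number from compound 2 to compound 4 (0.15 log units; within the scatter), and not clearly beyond the scatter in either direction. Compound 4 is estimated at 70 nM, with a range from 25 nM to 200 nM.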

Compound 4, half-maximal inhibitory concentration: 65 nM
Compound 4: middle estimate off by 1.1-fold (0.03 log units), on the high side; measured number inside the range.
By their numbers in this assay, from the lowest: compounds 3, 4 and 2 (each within the scatter of the next); then compound 1.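

In this assay, putting 1H-pyrazol-3-yl in place of 2-methyl-2H-tetrazol-5-yl gives a 1.5-fold lower number from compound 2 to compound 4 (0.19 log units; within the scatter), so these two compounds cannot be told apart. Going by these compounds alone, this is the first comparison here in which only one place differs, and it shows that, on this aromatic carbon meta to a large group, two quite different five-membered aromatic rings give numbers that cannot be separated: the group that leaves has 4 hetero atoms, 0 hydrogen-bond donors and 4 hydrogen-bond acceptors, while the group that enters has 2 hetero atoms, 1 hydrogen-bond donor and 1 hydrogen-bond acceptor. Nothing measured here explains why the swap leaves the two compounds indistinguishable.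

The compounds shown leave open what a carboxylic acid or a primary amine at this same place would do to the number, as both groups shown there are five-membered aromatic rings. They also leave open whether a plain phenyl ring, with no hetero atoms, would give a number that could be told apart from those of compound 2 and compound 4.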